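The source may report more compounds than this note shows. Statements on the series, on what has been measured and on what is new or still open speak of the compounds shown alone.

Series notes, cytotoxicity arm.

Compound 1 `CSc1cccc(C(=O)N2CCCC(C(=O)Nc3ccc(Cl)cc3)C2)c1` is the reference point of the pair measured so far. In an ADME assay on PC-3 cells (Homo sapiens) for cytotoxicity, read by WST assay, tested at 100 uM (a lower number here means less inhibition, a higher number more inhibition at the concentration tested (going by the name of the read-out)), compound 1 gives 0%. Compound 2 `O=C(c1ccccc1)c1cccc(C(=O)N2CCCC(C(=O)Nc3ccc(Cl)cc3)C2)c1` carries benzoyl where compound 1 carries methylsulfanyl, and in this assay compound 2 gives 0%. The one step measured, no change at the digits printed from compound 1 to compound 2 (within the scatter), shows that exchanging methylsulfanyl for benzoyl on that aromatic carbon leaves the read-out where it was; compound 2 therefore stands level with compound 1 at the digits shown, and neither compound shows any inhibition at the concentration tested.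

Compound 3 `Cc1nc(-c2cccc(C(=O)N3CCCC(C(=O)Nc4ccc(Cl)cc4)C3)c2)cs1` is the next member, not yet measured. Its change from compound 2 is 2-methyl-1,3-thiazol-4-yl in place of benzoyl on an aromatic carbon. Among the compounds with values here, the only step that bears on it is no change at the digits printed from compound 1 to compound 2 (within the scatter), which replaced one group at the same aromatic carbon without effect. On that basis no step beyond the scatter is expected in this assay from compound 2 to compound 3, the expected step being no change at the digits printed from compound 2 to compound 3 (within the scatter). For compound 3 the estimate in this assay is 0%, with an expected range from -8% to 12%.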

Compound 3, a percentage reported as inhibition, at one concentration (the size of the read-out at that concentration, not a potency): 1%
The estimate for compound 3 lay 1 percentage points below the measured number; low and high end bracket the measured number.
By their numbers in this assay, from the lowest: compounds 1, 2 and 3 (each within the scatter of the next).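

In this assay, the 2-methyl-1,3-thiazol-4-yl group in place of benzoyl on this aromatic carbon, meta to a large group, gives a step that stays within the scatter (a number 1 percentage points higher from compound 2 to compound 3 (within the scatter)), and the same group in place of methylsulfanyl does likewise (a number 1 percentage points higher from compound 1 to compound 3 (within the scatter)). The position has now taken a five-membered aromatic ring with 2 hetero atoms as well as a six-membered aromatic ring of carbon only and methylsulfanyl, and all three compounds read alike in this cell assay, so the earlier finding is no longer confined to a single exchange. No measured information on these groups is available to account for this result.

As far as these compounds go, it remains open whether an amine or a carboxylic acid on this aromatic carbon would also stay within the scatter of compound 3 (1%), or whether any group here moves the read-out at all. Also open, from the compounds shown here alone, is whether a change elsewhere on the shared core would shift the read-out in this assay.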